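Pyrrolidin-1-yl in place of morpholin-4-yl on a carbonyl carbon

A few compounds are considered here, and "the series" means these few. Any claim that something is new, unique, unknown or untested is made for them only; others in the source may bear on it.

In an in vivo functional assay on the whole organism for inhibition, with Rattus norvegicus as the target (on this read-out higher numbers stand for an effect only at larger amounts of compound and lower numbers for an effect already at smaller amounts), three compounds sharing one core have been measured. Compound 1 (`CCCCc1nc(C)c(CCC(=O)OCC)c(=O)n1Cc1ccc(-c2ccccc2-c2nnn[nH]2)cc1`) gives 0.066 mg/kg, compound 2 (`CCCCc1nc(C)c(CC(=O)N2CC(C)OC(C)C2)c(=O)n1Cc1ccc(-c2ccccc2-c2nnn[nH]2)cc1`) gives 0.029 mg/kg, and compound 3 (`CCCCc1nc(C)c(CCC(=O)N2CCOCC2)c(=O)n1Cc1ccc(-c2ccccc2-c2nnn[nH]2)cc1`) gives 0.143 mg/kg. Compound 3 therefore has the highest number of the three, and its gaps to both of the others lie beyond the scatter.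

Compound 4 (`CCCCc1nc(C)c(CCC(=O)N2CCCC2)c(=O)n1Cc1ccc(-c2ccccc2-c2nnn[nH]2)cc1`), still unmeasured, carries pyrrolidin-1-yl in place of morpholin-4-yl on a carbonyl carbon. The closest measured precedent involves the same carbonyl carbon: a 2.2-fold higher number from compound 1 to compound 3 (0.34 log units; beyond the scatter), with morpholin-4-yl in place of ethoxy. That modest step shows that the number can move with the group at this place. The other two steps, a 2.3-fold lower number from compound 1 to compound 2 (0.36 log units; beyond the scatter) and a 4.9-fold higher number from compound 2 to compound 3 (0.69 log units; beyond the scatter), are also modest, but they change more of the side chain and bear on this change less directly. Going by the values given here, no measured compound carries pyrrolidin-1-yl, so the direction remains uncertain. Since compound 1 and compound 2 both lie lower than compound 3, a small move toward a lower number is expected. The expected step is a 1.7-fold lower number from compound 3 to compound 4 (0.23 log units; within the scatter). For compound 4 the estimated value is 0.085 mg/kg, with an expected range from 0.03 mg/kg to 0.24 mg/kg.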

Compound 4, dose for half-maximal effect: 0.206 mg/kg
The estimate for compound 4 lay 2.4-fold (0.38 log units) below the measured number; the measured number falls inside the stated range.
By their numbers in this assay, from the lowest: compound 2; then compound 1; then compounds 3 and 4 (each within the scatter of the next).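

In this assay, pyrrolidin-1-yl in place of morpholin-4-yl on a carbonyl carbon gives a step within the scatter (a 1.4-fold higher number from compound 3 to compound 4 (0.16 log units; within the scatter)), so at this place the read-out does not separate the five-membered ring with no hydrogen-bond acceptor from the six-membered ring with one. Both rings stand apart from the ethoxy of compound 1 in the same direction (a 2.2-fold higher number from compound 1 to compound 3 (0.34 log units; beyond the scatter); a 3.1-fold higher number from compound 1 to compound 4 (0.49 log units; beyond the scatter)), and compound 2 stays well away from the new compound (a 7.1-fold higher number from compound 2 to compound 4 (0.85 log units; beyond the scatter)), although that last step alters more of the side chain than the ring alone. Nothing measured here accounts for these numbers.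

The compounds shown leave open whether a piperidin-1-yl ring, an open-chain diethylamino group or a free carboxylic acid on the same carbonyl carbon would stay with the two ring compounds or move toward compound 1. Going by these compounds alone, they also leave open how much of the low number of compound 2 belongs to the two methyl groups on its morpholine ring and how much to its shorter chain, as no compound here separates the two changes.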